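Carboxylic acid in place of morpholine amide on a second core

The source may hold more compounds than are shown below. What is called first, only, known or untested is meant among the compounds shown, and "the series" means these compounds.

The measured compounds and their numbers:
compound 1, `Cn1ncc2cc(-c3cnccc3/C=C/C(=O)N3CCOCC3)ccc21`, 356 nM;
compound 2, `Cn1ncc2cc(-c3cnccc3/C=C/C(=O)O)ccc21`, 34.6 nM;
compound 3, `Cn1ccc2cc(-c3cnccc3/C=C/C(=O)N3CCOCC3)ccc21`, 247 nM.

All three were tested in an assay on a protein complex for inhibition of CDK8/Cyclin C (Homo sapiens), with a stated time of 1 h; on this read-out lower numbers stand for stronger inhibition and higher numbers for weaker inhibition. Compound 1 and compound 2 share one core and differ in a single place: hydroxy in place of morpholin-4-yl on a carbonyl carbon. This change gave a 10-fold lower number from compound 1 to compound 2 (1.01 log units; beyond the scatter), so the acid is clearly the stronger inhibitor of the pair.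

Compound 3 carries the same morpholine amide as compound 1 but sits on a different core; the difference between the two cores is not broken down here. Its number and that of compound 1 lie within the usual scatter of each other, so nothing can be said about which of the two is stronger.

Compound 4, `Cn1ccc2cc(-c3cnccc3/C=C/C(=O)O)ccc21`, is not yet measured. It stands to compound 3 as compound 2 stands to compound 1: hydroxy in place of morpholin-4-yl on a carbonyl carbon. The place of the change is described in the same words for both pairs, so this is the same change on a second core.

The expectation rests on the one measured case of this change: because a 10-fold lower number from compound 1 to compound 2 (1.01 log units; beyond the scatter) was seen on the first core, a step of similar size is estimated for compound 4, namely a 9.9-fold lower number from compound 3 to compound 4 (0.99 log units; beyond the scatter). On that basis compound 4 is expected to give about 25 nM in this assay, with a plausible range from 10 nM to 65 nM. Going by the values given here, the range is wide, as only one earlier example of the change supports the estimate.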

Compound 4, half-maximal inhibitory concentration: 26.8 nM
The estimate for compound 4 lay 1.1-fold (0.03 log units) below the measured number; measured number inside the range.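

In this assay, putting hydroxy in place of morpholin-4-yl on the carbonyl carbon, which turns the morpholine amide into a carboxylic acid, gave a 9.2-fold lower number from compound 3 to compound 4 (0.96 log units; beyond the scatter) on the second core. The size of this step matches the one seen on the first core, so within these four compounds the change carries over from one core to the other with its effect essentially intact: the same change on two cores in this assay, a 10-fold lower number (1.01 log units; beyond the scatter) from compound 1 to compound 2 and a 9.2-fold lower number (0.96 log units; beyond the scatter) from compound 3 to compound 4, 1.1-fold (0.05 log units) apart, within the scatter of two such steps. Going by these compounds alone, this shows only that two cores, with one matched pair each, agree in this one assay; it does not show that the same step would appear on any further core, and the numbers alone do not explain why the acid gives the lower number on either core.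

The compounds shown leave open whether the lower number needs the carboxylic acid itself, since they include no methyl ester, no primary amide and no amide of a small open-chain amine such as dimethylamine at the same carbonyl carbon. They also leave open how a tetrazole in place of the carboxy group, or a longer chain carrying the carboxylic acid, would behave on these two cores.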